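The compounds below may be only part of what the source reports. "The series", "measured", "known", "first", "only" and "open" are said of these compounds alone.

Compound 2 `Cc1nc(CO)ccc1-c1cnc(NCc2c(F)ccc3c2CCO3)c2cn[nH]c(=O)c12` and compound 1 `Cn1nccc1-c1cnc(NCc2c(F)ccc3c2CCO3)c2cn[nH]c(=O)c12` share a core and differ in one group. In a physicochemical assay for lipophilicity, using the shake flask method, in phosphate buffer, measured as octanol-water partition, with a stated time of 30 min, at pH 7.4 (on this read-out lower numbers stand for lower lipophilicity and higher numbers for higher lipophilicity), compound 1 gives 2.6, and compound 2 gives 2.4; the shift a number 0.20 log units lower from compound 1 to compound 2 (within the scatter) keeps compound 2 level with compound 1 within the scatter. Compound 3 `O=C1CCCN1c1cnc(NCc2c(F)ccc3c2CCO3)c2cn[nH]c(=O)c12` is not yet measured; it carries 2-oxopyrrolidin-1-yl in place of 6-(hydroxymethyl)-2-methylpyridin-3-yl on an aromatic carbon. Among the measured compounds shown here, no measured step exchanges the 6-(hydroxymethyl)-2-methylpyridin-3-yl group for 2-oxopyrrolidin-1-yl, so the one step known, from compound 1 to compound 2, only shows that a change at this aromatic carbon can stay within the scatter. For compound 3 the expected step is a number 0.40 log units lower from compound 2 to compound 3 (beyond the scatter), a modest lowering, giving an estimate of 2 with a range from 1.5 to 2.5.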

Compound 3, distribution coefficient: 1.8
Compound 3: middle estimate off by 0.20 log units, on the high side; the measured number falls inside the stated range.
By their numbers in this assay, from the lowest: compound 3; then compounds 2 and 1 (each within the scatter of the next).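

Putting 2-oxopyrrolidin-1-yl on this aromatic carbon gives a number 0.60 log units lower from compound 2 to compound 3 (beyond the scatter) and a number 0.80 log units lower from compound 1 to compound 3 (beyond the scatter) in this assay. Among the compounds shown here, the one earlier exchange here, of one aromatic ring for another, stayed within the scatter, whereas replacing either aromatic ring with this non-aromatic ring goes beyond it. Nothing measured here gives the reason for this shift.

For the compounds shown here, with only one non-aromatic group at this position, the compounds cannot separate the effect of losing the aromatic ring from that of changing the group's size or adding the carbonyl. From the compounds shown here alone, how an open-chain amide or an amine such as piperidin-1-yl would read here remains open.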